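The compounds below may be only part of what the source reports. "The series", "measured", "known", "first", "only" and "open" are said of these compounds alone.

Measured so far:
Compound 1, `O=C(O)CCc1cccc2c1B(O)OC2`: > 100000 nM
Compound 2, `O=C(CCc1cccc2c1B(O)OC2)Nc1ccccc1-c1ccccc1`: 23000 nM
Compound 3, `O=C(CCc1cccc2c1B(O)OC2)Nc1cccc(-c2cccc(F)c2)c1`: 460 nM

In a functional assay on HCT-116 cells (Homo sapiens) for antiproliferative activity, read by MTT assay, with a stated time of 72 h (on this read-out lower numbers stand for stronger inhibition and higher numbers for weaker inhibition), compound 1 reaches only a limit, (the limit of > 100000 nM in this assay, at which 1 of the 3 values shown sits), and gives no number. Compound 2 gives 23000 nM in this assay. Compound 3, with 460 nM, stands lowest of the two numbers; the nearest, compound 2, sits well beyond the scatter above it.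

Compound 4, `O=C(CCc1cccc2c1B(O)OC2)Nc1cccc(-c2cccc(C(F)(F)F)c2)c1`, is not yet measured. It differs from compound 3 by trifluoromethyl in place of fluoro on an aromatic carbon. Among the compounds with values here, no measured pair shows this change, so its size is unknown here; a trifluoromethyl in place of fluoro is expected to move the number little, within or close to the scatter. For compound 4 an estimate of 400 nM is made, between 120 nM and 1500 nM, a step of a 1.2-fold lower number from compound 3 to compound 4 (0.06 log units; within the scatter).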

Compound 4, half-maximal inhibitory concentration: 580 nM
Compound 4: middle estimate off by 1.5-fold (0.16 log units), on the low side, within the range that was stated.
By their numbers in this assay, from the lowest: compounds 3 and 4 (each within the scatter of the next); then compound 2. At a limit, above all of these: compound 1.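

Trifluoromethyl in place of fluoro on an aromatic carbon gives, in this assay, a 1.3-fold higher number from compound 3 to compound 4 (0.10 log units; within the scatter) and is the first one-place step measured in this series. At this position, then, the two groups cannot be told apart on this read-out, and the number stays in the range set by compound 3. Nothing measured here gives a cause for this result.

As far as these compounds go, whether an amine, a carboxylic acid or a nitrile at this position would hold the number there stays open. So does the effect of a longer chain in place of the one carrying the amide.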